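This account rests on a few compounds, and the source may have more. Where it says the series, first, only, none or still open, it means among the compounds named here.

In a functional assay on MKN-1 cells (Homo sapiens) for inhibition, read by sulforhodamine B assay, with a stated time of 48 h (a higher number here means a weaker inhibitor of growth, a lower number a stronger inhibitor of growth), compound 1 `CCCCCCCCCCCC[C@@H](O)[C@H]1CC[C@H]([C@H](O)CCCCCCCCCCNC(=O)c2ccnn2C)O1` gives 43700 nM, the second highest of the three numbers. Compound 2 `CCCCCCCCCCCC[C@@H](O)[C@H]1CC[C@H]([C@H](O)CCCCCCCCCCNCc2ccnn2C)O1` gives 1410 nM and compound 3 `CCCCCCCCCCCC[C@@H](O)[C@H]1CC[C@H]([C@H](O)CCCCCCCCCCC(=O)Nc2ccnn2C)O1` gives 100000 nM. Compound 4 `CCCCCCCCCCCC[C@@H](O)[C@H]1CC[C@H]([C@H](O)CCCCCCCCCCOC(=O)c2ccnn2C)O1` carries ((1-methyl-1H-pyrazol-5-yl)carbonyl)oxy in place of ((1-methyl-1H-pyrazol-5-yl)carbonyl)amino on the saturated chain carbon: ((1-methyl-1H-pyrazol-5-yl)carbonyl)oxy in place of ((1-methyl-1H-pyrazol-5-yl)carbonyl)amino on a saturated chain carbon, ten or more bonds along the chain from an oxygen on a saturated carbon and a saturated ring carbon. Within the data shown here, two measured steps bear on this change. The modest 2.3-fold higher number from compound 1 to compound 3 (0.36 log units; beyond the scatter) keeps the carbonyl in the chain, as compound 4 does. The large 31-fold lower number from compound 1 to compound 2 (1.49 log units; beyond the scatter) replaces the carbonyl with methyl, which compound 4 does not do, so the modest step is the closer guide. A small shift towards a lower number is therefore expected, not beyond the scatter, and the estimated change is a 1.5-fold lower number from compound 1 to compound 4 (0.16 log units; within the scatter). For compound 4 the expected value is 30000 nM, with an estimated range of 6000 nM to 100000 nM.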

Compound 4, concentration for 50% growth inhibition: 43700 nM
Beside the measured number, compound 4's estimate is 1.5-fold (0.16 log units) below it; the measured number falls inside the stated range.
By their numbers in this assay, from the lowest: compound 2; then compounds 1 and 4 (each within the scatter of the next); then compound 3.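

In this assay ((1-methyl-1H-pyrazol-5-yl)carbonyl)oxy in place of ((1-methyl-1H-pyrazol-5-yl)carbonyl)amino gives no change at the digits printed from compound 1 to compound 4 (within the scatter) and shows that this chain position tolerates loss of the amide hydrogen. The direction of the link still registers, with a 2.3-fold lower number from compound 3 to compound 4 (0.36 log units; beyond the scatter) on going from (1-methyl-1H-pyrazol-5-yl)carbamoyl to the carbonyloxy group. The new link also stays far from the amine, with a 31-fold higher number from compound 2 to compound 4 (1.49 log units; beyond the scatter) as the gap.

As far as these compounds go, whether compound 2 owes its number to the amine nitrogen or to the missing carbonyl stays open, and an ether link at this chain carbon would separate the two. No evidence given here explains these numbers.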